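Isopropyl on the amidine nitrogen: cytotoxicity step carried across cores

The source may hold more compounds than are shown below. What is called first, only, known or untested is meant among the compounds shown, and "the series" means these compounds.

Compound 1 `N=C(N)c1ccc2cc(-c3cccc(OCCCCCCOc4ccccc4)c3)oc2c1` and compound 3 `N=C(N)c1ccc2oc(-c3ccc(OCCCOc4ccccc4)cc3)cc2c1` share the measured series with compound 2 `CC(C)NC(=N)c1ccc2cc(-c3cccc(OCCCCCCOc4ccccc4)c3)oc2c1`; the difference between the two cores of compound 1 and compound 3 is not broken down here. In an ADME assay on L6 cells (Rattus norvegicus) for cytotoxicity, read by resazurin assay, with a stated time of 70 h (on this read-out higher numbers stand for weaker inhibition and lower numbers for stronger inhibition), compound 1 gives 4300 nM, compound 2 gives 10100 nM, and compound 3 gives 7300 nM; the numbers of compound 2 and compound 3 lie within the scatter of each other, as do those of compound 1 and compound 3.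

Among the compounds with values here, the one measured step, isopropyl in place of hydrogen on an amine nitrogen, reads a 2.3-fold higher number from compound 1 to compound 2 (0.37 log units; beyond the scatter). Compound 4 `CC(C)NC(=N)c1ccc2oc(-c3ccc(OCCCOc4ccccc4)cc3)cc2c1` carries the same change on the core of compound 3 (isopropyl in place of hydrogen on an amine nitrogen).

For compound 4 in this assay the expected step is a 2.2-fold higher number from compound 3 to compound 4 (0.34 log units; beyond the scatter), resting only on the step of a 2.3-fold higher number from compound 1 to compound 2 (0.37 log units; beyond the scatter), since the change is the same and the two starting numbers are within scatter of each other. Compound 4 is estimated at 16000 nM, with a range from 8000 nM to 32000 nM.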

Compound 4, half-maximal inhibitory concentration: 45600 nM
Compound 4: the middle estimate sits 2.9-fold (0.45 log units) below what was measured, outside the stated range (above it).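

On the second core the amino to isopropylamino change in this assay again moves the number upward, a 6.2-fold higher number from compound 3 to compound 4 (0.80 log units; beyond the scatter), the same direction as a 2.3-fold higher number from compound 1 to compound 2 (0.37 log units; beyond the scatter), so in this series of two pairs the change weakens the cytotoxicity read-out on both cores. Within the data shown here, the larger second step does not establish a real difference between the cores, since the two steps agree within what repeated steps of this kind would show: the same change on two cores in this assay, a 2.3-fold higher number (0.37 log units; beyond the scatter) from compound 1 to compound 2 and a 6.2-fold higher number (0.80 log units; beyond the scatter) from compound 3 to compound 4, 2.7-fold (0.42 log units) apart, within the scatter of two such steps With only two pairs, the direction holds for these cores alone, and neither a general size for the step nor any core dependence of that size can be drawn from them.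

From the compounds shown here alone, whether a smaller ethyl group or a ring such as cyclopentyl on the same amine nitrogen would move the number in the same direction stays open. So does whether the isopropyl step would hold on a core carrying a longer chain or an added carboxylic acid.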